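Mirror Image of Compound 2: Clearance in Rat Liver Microsomes

A few compounds are considered here, and "the series" means these few. Any claim that something is new, unique, unknown or untested is made for them only; others in the source may bear on it.

Measured so far:
- compound 1, `C[C@]1(c2ccc(OC(F)(F)F)cc2)C[C@@](O)(c2ccccn2)CO1`, gives 150 mL/min/kg
- compound 2, `O[C@]1(c2ccccn2)CC[C@H](c2ccc(C(F)(F)F)cc2)C1`, gives 1430 mL/min/kg
- compound 3, `O[C@H](c1ccccn1)[C@]1(c2ccc(Cl)c(Cl)c2)CCO1`, gives 50 mL/min/kg

All three numbers come from an ADME assay on liver for metabolic stability, with Liver microsome (Rattus norvegicus) as the target, read by LC-MS, using microsomes, with a stated time of 5 h; a lower number here means slower removal, a higher number faster removal of the compound. On these numbers compound 2 stands highest: its nearest neighbour is compound 1, whose number is lower by a gap beyond the usual scatter, and compound 3 lies further away still, again beyond the scatter. Compound 2 is therefore the one that is removed fastest among the three.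

The next compound to be measured is compound 4, `O[C@@]1(c2ccccn2)CC[C@@H](c2ccc(C(F)(F)F)cc2)C1`. Compared with compound 2 the change is this: the two compounds have the same atoms and bonds and differ only in configuration as drawn: 2 of 2 stereo elements differ (all stereocentres are inverted: mirror images); a stereocentre at a saturated ring carbon is drawn R in compound 2 and S in compound 4; a stereocentre at a saturated ring carbon is drawn S in compound 2 and R in compound 4. Nothing is added and nothing is taken away; the two compounds are mirror images of each other.

Among the compounds with values here, no pair of measured compounds shows what a change of this kind does in this assay, so there is no step to lean on. The expectation is a step from compound 2 to compound 4 of a 1.2-fold lower number from compound 2 to compound 4 (0.08 log units; within the scatter), that is, no change beyond the scatter in either direction. For compound 4 the estimated number is 1200 mL/min/kg, with a range from 400 mL/min/kg to 3500 mL/min/kg.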

Compound 4, clearance: 2520 mL/min/kg
Compound 4: the middle estimate sits 2.1-fold (0.32 log units) below what was measured; measured number inside the range.
By their numbers in this assay, from the lowest: compound 3; then compound 1; then compounds 2 and 4 (each within the scatter of the next).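

In this assay, turning the molecule into its mirror image gives a 1.8-fold higher number from compound 2 to compound 4 (0.25 log units; within the scatter), so inverting both stereocentres at once does not separate this pair in how quickly the compounds are removed. The very high number is therefore not confined to one mirror form of this structure, since compound 2 gives 1430 mL/min/kg and compound 4 gives 2520 mL/min/kg, and neither form offers a way out of fast removal. This is the first comparison here in which a single kind of change can be read on its own, and it can be read cleanly because nothing else separates the pair: the fact that compounds 2 and 4 differ only in the configuration as drawn

On these data alone, the result speaks only to inverting both stereocentres together, so it remains open what inverting just one of them would do to the number, since such a compound would not be a mirror image of either and need not behave like them. As far as these compounds go, it also remains open whether replacing the trifluoromethyl group with a carboxylic acid or an amine would lower the number in either mirror form, and whether the two forms would then still match.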